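Notes on the step to compound 4

The compounds below may be only part of what the source reports. "The series", "measured", "known", "first", "only" and "open" are said of these compounds alone.

- compound 1 `Cc1cc(C)cc(S(=O)(=O)c2c(C(=O)NCC(=O)NC(C)c3ccccc3)[nH]c3ccc(Cl)cc23)c1`: 29400 nM
- compound 2 `Cc1cc(C)cc(S(=O)(=O)c2c(C(=O)NC(C)C(=O)NCCn3c(C)cnc3[N+](=O)[O-])[nH]c3ccc(Cl)cc23)c1`: 16000 nM
- compound 3 `Cc1cc(C)cc(S(=O)(=O)c2c(C(=O)NCc3cccc(N)c3)[nH]c3ccc(Cl)cc23)c1`: > 53400 nM

All three were measured in an ADME assay on MT4 cells (Homo sapiens) for cytotoxicity, read by MTT assay; on this read-out higher numbers stand for lower toxicity in this test and lower numbers for higher toxicity in this test. In this assay, compound 2 at 16000 nM lies within the usual scatter of compound 1 at 29400 nM. The value of compound 3, > 53400 nM, is a limit of the assay and not a number.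

The next compound is compound 4 `Cc1cc(C)cc(S(=O)(=O)c2c(C(=O)NC(C)C(=O)NC(C)c3ccccc3)[nH]c3ccc(Cl)cc23)c1`, which differs from compound 2 as follows: a group of 8 heavy atoms (8 carbon; one six-membered aromatic ring of carbon only) in place of a group of 11 heavy atoms (6 carbon, 3 nitrogen, 2 oxygen; one five-membered aromatic ring with 2 hetero atoms), on an amide-type nitrogen. In words, 1-phenylethyl enters in place of a group of 11 heavy atoms with one five-membered aromatic ring with 2 hetero atoms, on an amide-type nitrogen.

Going by the values given here, only one measured step bears on this, and only loosely: an at least 1.8-fold higher number from compound 1 to compound 3 (0.25 log units; that floor lies within the scatter). It too changes the group carried on the chain, and its floor stays within the scatter. The entering 1-phenylethyl is also found in compound 1, at 29400 nM. A change beyond the scatter is therefore not expected, though a slightly higher number is the likelier direction. The expected step is a 1.6-fold higher number from compound 2 to compound 4 (0.19 log units; within the scatter). For compound 4 the estimate is 25000 nM, with an expected range of 11000 nM to 55000 nM.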

Compound 4, half-maximal cytotoxic concentration: 21700 nM
Compound 4: middle estimate off by 1.2-fold (0.06 log units), on the high side, within the range that was stated.
By their numbers in this assay, from the lowest: compounds 2, 4 and 1 (each within the scatter of the next). At a limit, above all of these: compound 3.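

In this assay, exchanging the group of 11 heavy atoms with its five-membered aromatic ring for 1-phenylethyl on the amide-type nitrogen gives a 1.4-fold higher number from compound 2 to compound 4 (0.13 log units; within the scatter), so this large change of atoms and ring type at this place does not carry the number beyond the scatter. At the chain carbon, methyl in place of hydrogen gives a 1.4-fold lower number from compound 1 to compound 4 (0.13 log units; within the scatter), which is likewise within the scatter and adds a second place where one change leaves the read-out unmoved within the usual variation. Unlike the earlier step to compound 3, which offered only a floor, both of these steps have a number at each end, and they show that the amide-type nitrogen and the saturated chain carbon can each be changed in this pair of comparisons without a readable shift.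

On these data alone, the value of compound 3 is a limit and not a number, so its distance from the other compounds cannot be read: the limit of > 53400 nM in this assay, at which 1 of the 4 values shown sits. Whether a carboxylic acid or a longer chain on the amide-type nitrogen would also stay within the scatter remains open.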